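Aryl swap on the triazole of compound 1

The source may hold more compounds than are shown below. What is called first, only, known or untested is meant among the compounds shown, and "the series" means these compounds.

Among the compounds with values here, in an ADME assay on HFF cells (Homo sapiens) for cytotoxicity, read by MTT assay, with a stated time of 72 h (on this read-out lower numbers stand for stronger inhibition and higher numbers for weaker inhibition), compound 1 `O=C1O[C@H]([C@@H](O)Cn2cc(-c3ccc(Br)cc3)nn2)C(OCc2ccccc2)=C1OCc1ccccc1` gives 5100 nM, the only number in the set. Compound 2 `CCCCCc1ccc(-c2cn(C/C=C3\OC(=O)C(OCc4ccccc4)=C3OCc3ccccc3)nn2)cc1` returns only a limit in this assay, > 100000 nM. Compound 3 `COc1ccccc1-c1cn(C/C=C2\OC(=O)C(OCc3ccccc3)=C2OCc2ccccc2)nn1` likewise returns only a limit in this assay, > 100000 nM. The step that the two limits leave unreadable from compound 2 to compound 3 stays unreadable because both values sit at the limit of > 100000 nM in this assay, at which 2 of the 3 values shown sit. Compound 4 `O=C1O[C@H]([C@@H](O)Cn2cc(-c3cc(F)cc(F)c3)nn2)C(OCc2ccccc2)=C1OCc1ccccc1` carries 3,5-difluorophenyl in place of 4-bromophenyl on an aromatic carbon. Within the data shown here, no measured step changes the aryl group on the shared core of compound 1, so nothing sets a size or direction for this change, and no shift beyond the scatter is expected in this assay. The estimate for compound 4 is 6000 nM, with a range of 2500 nM to 20000 nM. The expected step is a 1.2-fold higher number from compound 1 to compound 4 (0.07 log units; within the scatter).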

Compound 4, half-maximal inhibitory concentration: > 100000 nM
Compound 4: a limit, no number; the forecaster's own chance of this, stated with the estimate: 15%; middle value at least 16-fold (1.22 log units) away from the limit.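

In this assay, the aryl group at this position on the shared core of compound 1 proves far from neutral: 3,5-difluorophenyl in place of 4-bromophenyl gives an at least 19-fold higher number from compound 1 to compound 4 (1.29 log units; beyond the scatter). Within the data shown here, no earlier pair showed a readable step for an aryl change on this core. Compound 4 gives a limit and not a number: the limit of > 100000 nM in this assay, at which 3 of the 4 values shown sit.

Going by these compounds, the full size of the step stays open, and one pair cannot separate loss of the bromine from the arrival of the two fluorines. On these data alone, whether a plain phenyl or a 4-chlorophenyl on this core would stay near compound 1 also remains open.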